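Adding Methoxy to a Weakly Cytotoxic Compound

The compounds below may be only part of what the source reports. "The series", "measured", "known", "first", "only" and "open" are said of these compounds alone.

compound 1 `COc1ccc2c(/C=C(\C#N)C(=O)c3c[nH]c4cc(OC)ccc34)c[nH]c2c1`: > 50000 nM
compound 2 `N#C/C(=C\c1c[nH]c2cc(F)ccc12)C(=O)c1c[nH]c2ccccc12`: 23500 nM

For the measured compounds named here, in a functional assay on MIA PaCa-2 cells (Homo sapiens) for cytotoxicity, read by WST assay, with a stated time of 24 h (on this read-out lower numbers stand for stronger inhibition and higher numbers for weaker inhibition), compound 2 gives 23500 nM, the only actual number among the two compounds measured so far. Compound 1 gives > 50000 nM, which is a limit of the assay and not a number. Compound 2 therefore offers a single numerical anchor, and its reading shows only weak inhibition on this scale.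

Compound 3 `COc1ccc2c(C(=O)/C(C#N)=C/c3c[nH]c4cc(F)ccc34)c[nH]c2c1` follows from compound 2 by one structural change, with methoxy in place of hydrogen on an aromatic carbon. Going by the values given here, no measured step between two compounds that differ in one place is available as a guide. The expectation leans on compound 1, which also carries methoxy and whose > 50000 nM is a limit. A modest move toward weaker inhibition in this assay is therefore expected, possibly not beyond the usual scatter. The expected change is a 1.3-fold higher number from compound 2 to compound 3 (0.11 log units; within the scatter). For compound 3, the estimated value is 30000 nM, with an expected range of 10000 nM to 50000 nM.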

Compound 3, half-maximal inhibitory concentration: > 50000 nM
Compound 3 was reported as a limit (the forecaster's own chance of this, stated with the estimate: 35%); middle value at least 1.6-fold (0.22 log units) away from the limit.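

In this assay compound 3 gives > 50000 nM, which is a limit of the assay and not a number. Methoxy in place of hydrogen on an aromatic carbon of a six-membered aromatic ring of carbon only, meta to a fused ring and para to a fused ring, gives an at least 2.1-fold higher number from compound 2 to compound 3 (0.32 log units; beyond the scatter), the first readable step here, and shows that this change at this position moves the already weak compound further toward weaker inhibition. How far the change goes cannot be told, and the step between the two limits of compound 1 and compound 3 cannot be read: the limit of > 50000 nM in this assay, at which 2 of the 3 values shown sit.

The compounds shown leave open whether this move belongs to methoxy itself or would also come with another group at this position, such as a hydroxyl, an amine or a longer ether chain like ethoxy. They also leave open whether any group at this position could give a lower number than compound 2 at 23500 nM.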